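Swapping the anilide ring on an oleic amide

This account rests on a few compounds, and the source may have more. Where it says the series, first, only, none or still open, it means among the compounds named here.

Compound 1 `CCCCCCCC/C=C/CCCCCCCC(=O)Nc1ccccc1CC` was examined in an assay on microsomes from intestine for inhibition of acyl-CoA:cholesterol acyltransferase (Oryctolagus cuniculus) (on this read-out higher numbers stand for weaker inhibition and lower numbers for stronger inhibition), where compound 1 gives 1200 nM. Among the two numbers recorded this is the highest; its nearest neighbour, compound 2 `CCCCCCCC/C=C/CCCCCCCC(=O)Nc1cc(Cl)c(OC)cc1OC`, gives 520 nM in this assay, a lower number that lies beyond the usual scatter. Among the compounds with values here, no step between measured compounds that differ in a single place is available. Compound 3 `CCCCCCCC/C=C/CCCCCCCC(=O)Nc1c(C)cccc1OC` has not yet been measured in this assay. It differs from compound 1 in one place: 2-methoxy-6-methylphenyl in place of 2-ethylphenyl on an amide-type nitrogen. The entering ring carries a methoxy group, as does the ring of compound 2, which in this assay gives 520 nM. On that comparison alone a moderate drop in the number is expected. Compound 3 is therefore estimated at 500 nM, within a range from 150 nM to 1600 nM. The step this estimate means, a 2.4-fold lower number from compound 1 to compound 3 (0.38 log units; beyond the scatter), is expected to be downward and of a size just beyond the scatter.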

Compound 3, half-maximal inhibitory concentration: 20 nM
Estimate against measurement, compound 3: 25-fold (1.40 log units) above; measured number below the stated range.
By their numbers in this assay, from the lowest: compound 3; then compound 2; then compound 1.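

In this assay, the group on the amide-type nitrogen proves to be a powerful point of change: 2-methoxy-6-methylphenyl in place of 2-ethylphenyl gives a 60-fold lower number from compound 1 to compound 3 (1.78 log units; beyond the scatter), with the rest of the molecule the same. The entering group holds one hydrogen-bond acceptor where the leaving group holds none, but its methoxy and methyl groups arrive together in this single step, so their shares of the change cannot be told apart. Nothing at hand accounts for the size of this step.

The compounds shown leave open whether either group alone would give a similar number, and whether a hydroxyl or a fluorine could stand in for the methoxy group. They also leave open whether the same ring would hold its number on a shorter chain.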